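The compounds below may be only part of what the source reports. "The series", "measured", "known", "first", "only" and "open" are said of these compounds alone.

Measured compounds in a functional assay on CCRF-CEM cells for agonist activity at C-X-C chemokine receptor type 4 (Homo sapiens), read by calcium flux, with a stated time of 25 min; on this read-out lower numbers stand for an effect already at smaller amounts and higher numbers for an effect only at larger amounts of compound; each value given is a limit of the assay, not a number:

Compound 1 `Cc1cnc(CN(C)C[C@H]2Cc3c(cccc3N3CCNCC3)CN2)c(C)c1` gives > 30000 nM.
Compound 2 `CN(C[C@H]1Cc2c(cccc2N2C[C@@H]3C[C@H]2CN3)CN1)[C@H]1CCCc2cccnc21` gives > 30000 nM.
Compound 3 `CN(C[C@@H]1Cc2c(cccc2N2CCNCC2)CN1)[C@H]1CCCc2cccnc21` gives > 30000 nM.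

Compound 2 stands at the same limit as the other two; its value in this assay is a limit only, so no order among the three can be read from the numbers. Within the data shown here, the whole set sits at the limit of > 30000 nM in this assay, at which 3 of the 3 values shown sit, and no step between two measured compounds can be sized.

The next compound, compound 4 `CC(C)N1CCN(c2cccc3c2C[C@H](CN(C)[C@H]2CCCc4cccnc42)NC3)CC1`, is still to be measured in this assay. It differs from compound 2 in one place: a group of 9 heavy atoms (7 carbon, 2 nitrogen; one six-membered non-aromatic ring with 2 hetero atoms) in place of a group of 7 heavy atoms (5 carbon, 2 nitrogen; 2 five-membered non-aromatic rings with 1 hetero atom each), on an aromatic carbon. The change concerns the group on the aromatic carbon, ortho to a fused ring and meta to a fused ring, while the rest of the shared core is kept.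

Among the measured compounds shown here, with every measured value at the limit, there is no measured step to lean on; the change is expected to give no step beyond the scatter, and compound 4 is expected most likely to remain at the limit as well, since compound 2 sits at > 30000 nM. The step from compound 2 to compound 4 is estimated as a number no higher from compound 2 to compound 4 (the limit leaves the size open). For compound 4 the expected value is 30000 nM, in the range 10000 nM to 100000 nM.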

Compound 4, half-maximal effective concentration: > 30000 nM
Compound 4 gave a limit, no number; the forecaster's own chance of this, stated with the estimate: 80%; the middle value sits exactly at the limit.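

Compound 4 gives > 30000 nM, a limit and not a number. Among these compounds, compound 2 also stands at a limit, so no step from compound 2 to compound 4 can be read. The compounds shown leave open whether any change to the shared core or the group on the aromatic carbon would give a measurable value: the limit of > 30000 nM in this assay, at which 4 of the 4 values shown sit.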